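The source may hold more compounds than are shown below. What is called first, only, known or untested is meant among the compounds shown, and "the series" means these compounds.

Compound 1, whose structure is `COc1ccc2[nH]c3c4cn[nH]c4c4c(c3c2c1)C(=O)NC4=O`, and compound 2, whose structure is `Cc1ccc2[nH]c3c4cn[nH]c4c4c(c3c2c1)C(=O)NC4=O`, share a core of five fused rings. In a functional assay on PC-3 cells (Homo sapiens) for cytotoxicity, read by MTT assay, with a stated time of 72 h (on this read-out higher numbers stand for weaker inhibition and lower numbers for stronger inhibition), compound 1 gives only a limit of the assay, > 100000 nM. In this assay compound 2 likewise gives only a limit, > 100000 nM. The change from compound 1 to compound 2 is methyl in place of methoxy on an aromatic carbon and its step in this assay is a step that the two limits leave unreadable from compound 1 to compound 2, because both values sit at the limit of > 100000 nM in this assay, at which 3 of the 3 values shown sit.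

Compound 3, whose structure is `COc1ccc2[nH]c(-n3cccn3)cc2c1`, has a different, smaller core; the difference between the two cores is not broken down here. In this assay compound 3 gives only a limit, > 100000 nM. Compound 4, whose structure is `Cc1ccc2[nH]c(-n3cccn3)cc2c1`, has not yet been measured in this assay. Its change from compound 3 is methyl in place of methoxy on an aromatic carbon, the same kind of change as from compound 1 to compound 2, but here the ring is part of a fused or bridged system of two rings rather than five.

Since the same kind of change left compound 1 and compound 2 both at the limit, the step expected from compound 3 to compound 4 is a step that the limit leaves unreadable from compound 3 to compound 4. Compound 4 is therefore estimated at 150000 nM in this assay.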

Compound 4, half-maximal inhibitory concentration: > 100000 nM
Compound 4: only a limit was reported; the forecaster's own chance of this, stated with the estimate: 85%; the middle value lies beyond the limit too.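

In this assay compound 4 gives only a limit, > 100000 nM. No step can be read from compound 3 to compound 4, because the values shown all rest at the same limit: the limit of > 100000 nM in this assay, at which 4 of the 4 values shown sit.

The compounds shown leave open whether methyl in place of methoxy on an aromatic carbon changes cytotoxicity on either core.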